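This account rests on a few compounds, and the source may have more. Where it says the series, first, only, none or still open, it means among the compounds named here.

Measured compounds and values:

Compound 1, `COc1ccc(C(=O)N2C[C@H](Oc3nccc(C#N)c3C)CC[C@H]2C)c(-n2nccn2)n1`: 21 nM
Compound 2, `COC(=O)c1cccnc1N[C@@H]1CC[C@@H](C)N(C(=O)c2ccccc2-n2nccn2)C1`: 38 nM
Compound 3, `Cc1c(C#N)ccnc1O[C@@H]1CC[C@@H](C)N(C(=O)c2ccccc2C(F)(F)F)C1`: 21 nM

In a functional assay on cells for antagonist activity at Orexin receptor type 2 (Homo sapiens), read by FLIPR and calcium flux (on this read-out lower numbers stand for stronger inhibition and higher numbers for weaker inhibition), compound 3 gives 21 nM, level with compound 1 at the digits shown; together they are the lowest two numbers of the three. Compound 2 gives 38 nM, which stands within the scatter of compound 3, so no order between the two can be claimed.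

The next member of the series is compound 4, `Cc1c(C#N)ccnc1O[C@@H]1CC[C@@H](C)N(C(=O)c2ccccc2-n2ncnn2)C1`. It differs from compound 3 in one place: 2H-tetrazol-2-yl in place of trifluoromethyl on an aromatic carbon. Compound 1 differs from compound 3 only in the group that in compound 3 is trifluoromethyl, and in this assay compound 1 gives 21 nM, level with compound 3. Compound 2, which carries a similar change on a shorter core, gives 38 nM. Both numbers suggest that exchanging trifluoromethyl for a small aromatic ring at this place leaves the potency near that of compound 3.

The step expected in this assay from compound 3 to compound 4 is therefore a 1.4-fold higher number from compound 3 to compound 4 (0.15 log units; within the scatter), which is no change beyond the scatter. Compound 4 is expected to give about 30 nM, with a range from 10 nM to 90 nM.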

Compound 4, half-maximal inhibitory concentration: 7.7 nM
Compound 4: the middle estimate sits 3.9-fold (0.59 log units) above what was measured; measured number below the stated range.
By their numbers in this assay, from the lowest: compound 4; then compounds 1, 3 and 2 (each within the scatter of the next).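

In this assay, among these compounds, 2H-tetrazol-2-yl in place of trifluoromethyl on an aromatic carbon, ortho to a large group, gives a 2.7-fold lower number from compound 3 to compound 4 (0.44 log units; beyond the scatter) and so provides the first single-place step, showing that the number responds to what this place carries, though only modestly. The change brings in a five-membered aromatic ring with 4 hetero atoms and hydrogen-bond acceptors where the leaving group has no ring and no acceptors, so ring and acceptors enter together and this one step cannot separate them. No measurement shown here speaks to the cause of the step.

Among the compounds shown here, only this one pair can be read at this place, so it remains open whether a simple amine, a carboxylic acid or a longer alkyl chain at the same aromatic carbon would move the number in the same direction. On these data alone, it also remains open whether the tetrazole ring would give a similar step on the cores of compound 1 and compound 2, which carry other groups and differ in more than one place.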